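Removing the aromatic fluoro in two linker variants

The compounds below may be only part of what the source reports. "The series", "measured", "known", "first", "only" and "open" are said of these compounds alone.

Compound 1 `COc1cc2nc(Nc3ccc(S(C)(=O)=O)cc3F)nc(OCC3CCN(C(=O)OC(C)(C)C)CC3)c2cc1OC` and compound 2 `COc1cc2nc(Nc3ccc(S(C)(=O)=O)cc3)nc(OCC3CCN(C(=O)OC(C)(C)C)CC3)c2cc1OC` share one core; compound 3 `COc1cc2nc(Nc3ccc(S(C)(=O)=O)cc3F)nc(OC3CCN(C(=O)OC(C)(C)C)CC3)c2cc1OC` and compound 4 `COc1cc2nc(Nc3ccc(S(C)(=O)=O)cc3)nc(OC3CCN(C(=O)OC(C)(C)C)CC3)c2cc1OC` share another. The difference between the two cores is not broken down here.

In a functional assay on HEK293 cells for agonist activity at Glucose-dependent insulinotropic receptor (Homo sapiens), read by cAMP accumulation, with a stated time of 60 min (a lower number here means a smaller maximal response, a higher number a larger maximal response), compound 1 gives 21.3%. Compound 2 gives 17.4%. The change from compound 1 to compound 2 is hydrogen in place of fluoro on an aromatic carbon, and the step it made was a number 3.9 percentage points lower from compound 1 to compound 2 (within the scatter). Compound 3 gives 19.7%, which sits close to compound 1 and compound 2, all three within the usual scatter of one another.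

The change from compound 3 to compound 4 is hydrogen in place of fluoro on an aromatic carbon, the same kind of change as before, at the same place: ortho to a large group and meta to a methylsulfonyl group. The expected step is a number 3.7 percentage points lower from compound 3 to compound 4 (within the scatter), because the same change gave a number 3.9 percentage points lower from compound 1 to compound 2 (within the scatter). Compound 4 is therefore expected near 16% in this assay. For compound 4 the expected range runs from 9% to 24%.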

Compound 4, largest response reached (Emax), in percent of the reference or control that the assay uses: 20.6%
Estimate against measurement, compound 4: 4.6 percentage points below; the measured number falls inside the stated range.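

In this assay, the change from 2-fluoro-4-(methylsulfonyl)phenyl to 4-(methylsulfonyl)phenyl on the second core gives a number 0.9 percentage points higher from compound 3 to compound 4 (within the scatter). The two steps for this change can be set side by side: the same change on two cores in this assay, a number 3.9 percentage points lower (within the scatter) from compound 1 to compound 2 and a number 0.9 percentage points higher (within the scatter) from compound 3 to compound 4, 4.8 percentage points apart, within the scatter of two such steps. Within this pair of cores, the swap of fluoro for hydrogen therefore carries over with no difference that can be told from the scatter, but since neither step stands clear of the scatter, this does not show that the fluoro raises or lowers the maximal response on either core, and it says nothing about any other core or read-out.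

Still open, from the compounds shown here alone, is whether a chloro, a methyl or a nitrile on the same aromatic carbon would give a step that stands clear of the scatter. Also open, going by these compounds, is how the same change behaves when the methylsulfonyl group gives way to a carboxylic acid or a sulfonamide, or when the tert-butyl carbamate gives way to a free amine.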